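The source may hold more compounds than are shown below. What is called first, only, known or untested is meant among the compounds shown, and "the series" means these compounds.

Working notes on the series, all read in a functional assay on U-87MG ATCC cells for inhibition, with U-87 MG (Homo sapiens) as the target, read by MTT assay, with a stated time of 48 h; a lower number here means a stronger inhibitor, a higher number a weaker inhibitor. Here compound 1 `N#Cc1ccc(-c2nc3ccccn3c2Sc2ccccc2)cc1` gives 65500 nM, a weak but measurable result. Compound 2 `Cc1ccc2nc(-c3ccc(Cl)cc3)c(Sc3ccccc3)n2c1` gives no number, only a limit of the assay, > 100000 nM. Compound 3 `Clc1ccc(-c2nc3ccccn3c2Sc2ccccc2)cc1` differs from compound 2 in one place, with hydrogen in place of methyl on an aromatic carbon. Among the measured compounds shown here, no measured pair gauges this change, and the limit leaves the true size of any step open. The nearest guide is compound 1 at 65500 nM, which also has hydrogen on that carbon. A modest move toward stronger inhibition is therefore expected, with the estimated step being an at least 1.4-fold lower number from compound 2 to compound 3 (0.15 log units; that floor lies within the scatter). A second limit remains possible. The estimate for compound 3 is 70000 nM, with an expected range of 30000 nM to 130000 nM.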

Compound 3, half-maximal inhibitory concentration: 30200 nM
Beside the measured number, compound 3's estimate is 2.3-fold (0.37 log units) above it; measured number inside the range.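

In this assay, on these data alone, hydrogen in place of methyl on this aromatic carbon gives an at least 3.3-fold lower number from compound 2 to compound 3 (0.51 log units; beyond the scatter), so the change now has a floor beyond the scatter, though its full size remains unknown. That step can be read only as a floor because compound 2 stands at a limit of the assay, not at a number: the limit of > 100000 nM in this assay, at which 1 of the 3 values shown sits. With hydrogen on that carbon in both compounds, chloro in place of cyano on the other aromatic carbon gives a 2.2-fold lower number from compound 1 to compound 3 (0.34 log units; beyond the scatter), showing that this second place also moves the read-out.

As far as these compounds go, only methyl and hydrogen appear on the ring carbon, so it remains open how a methoxy group or a fluorine there would read. At the other place, only chloro and cyano appear, leaving an amine or a trifluoromethyl group open.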